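Ring size at the amino nitrogen: cyclopentyl to cyclobutyl

This account rests on a few compounds, and the source may have more. Where it says the series, first, only, none or still open, it means among the compounds named here.

Compound 1 `CCCn1c(-c2ccccc2)nc2c(N)ncnc21` carries an unsubstituted amino group on the shared core, and in a functional assay on CHO cells for antagonist activity at adenosine receptor A2b (Homo sapiens), read by 33P incorporation, with a stated time of 20 min (on this read-out higher numbers stand for weaker inhibition and lower numbers for stronger inhibition), compound 1 gives 1040 nM. Compound 2 `CCCn1c(-c2ccccc2)nc2c(NC3CCOC3)ncnc21` gives 9080 nM in this assay, and compound 3 `CCCn1c(-c2ccccc2)nc2c(NC3CCCC3)ncnc21` gives 3430 nM. Among the three numbers compound 3 stands second highest: a 2.6-fold lower number from compound 2 to compound 3 (0.42 log units; beyond the scatter), while a 3.3-fold higher number from compound 1 to compound 3 (0.52 log units; beyond the scatter). Compound 4 `CCCn1c(-c2ccccc2)nc2c(NC3CCC3)ncnc21` differs from compound 3 only as follows: cyclobutyl in place of cyclopentyl on a nitrogen on an aromatic ring.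

Within the data shown here, no measured step changes the size of a carbon ring on this nitrogen, so the bearing of the earlier steps is indirect. The step from compound 1 to compound 3 shows that the five-membered carbon ring on the nitrogen costs a modest step in this assay, and an 8.7-fold higher number from compound 1 to compound 2 (0.94 log units; beyond the scatter) shows a larger cost for the five-membered ring containing oxygen. The four-membered carbon ring that enters is a smaller substituent than the cyclopentyl that leaves, and nothing measured says whether a smaller ring returns part of that cost. For compound 4 a step within the scatter, or a small move toward lower numbers, is expected in this assay: a 1.4-fold lower number from compound 3 to compound 4 (0.14 log units; within the scatter). Compound 4 is therefore estimated at 2500 nM, with a range from 1000 nM to 6500 nM.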

Compound 4, inhibition constant: 774 nM
The estimate for compound 4 lay 3.2-fold (0.51 log units) above the measured number, and the stated range ends above it.
By their numbers in this assay, from the lowest: compounds 4 and 1 (each within the scatter of the next); then compound 3; then compound 2.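

In this assay, among these compounds, the read-out responds to the size of a carbon ring on this nitrogen: cyclobutyl in place of cyclopentyl gives a 4.4-fold lower number from compound 3 to compound 4 (0.65 log units; beyond the scatter), the first measured change of carbon ring size at this place. A substituent on the amino nitrogen therefore does not carry a cost in every case: the cyclopentyl and oxolan-3-yl groups both gave higher numbers than hydrogen, whereas cyclobutyl gives a 1.3-fold lower number from compound 1 to compound 4 (0.13 log units; within the scatter), which leaves compound 1 and compound 4 indistinguishable in this read-out. The four-membered carbon ring also marks the widest gap in the set, a 12-fold lower number from compound 2 to compound 4 (1.07 log units; beyond the scatter), although this step changes ring size and removes the ring oxygen together, so the two contributions cannot be separated.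

From the compounds shown here alone, whether cyclopropyl would extend the move toward lower numbers, and how cyclohexyl, an open chain such as isopropyl or the oxygen-containing oxetan-3-yl would compare with cyclobutyl on this nitrogen, remains open. Nothing available accounts for the step from cyclopentyl to cyclobutyl.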